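Moving the Ring Nitrogen on the Amide Nitrogen Substituent

The compounds below may be only part of what the source reports. "The series", "measured", "known", "first", "only" and "open" are said of these compounds alone.

Compound 2 `CCCc1nc(CC)c(C(=O)CCN(C(=O)c2cccnc2)c2cccnc2)n1Cc1ccc(-c2ccccc2S(=O)(=O)NC(=O)OCCC(C)C)cc1F` gives 0.22 nM in an assay on isolated protein for inhibition of Type-2 angiotensin II receptor (Rattus norvegicus) (on this read-out lower numbers stand for stronger inhibition and higher numbers for weaker inhibition), the lowest of the two numbers recorded. Its closest neighbour, compound 1 `CCCc1nc(CC)c(C(=O)CCN(C(=O)c2ccncc2)c2cccnc2)n1Cc1ccc(-c2ccccc2S(=O)(=O)NC(=O)OCCC(C)C)cc1F`, gives 1 nM in this assay, and the step of a 4.5-fold lower number from compound 1 to compound 2 (0.66 log units; beyond the scatter) shows what shifting the ring nitrogen of the group on the carbonyl carbon did. Compound 3 `CCCc1nc(CC)c(C(=O)CCN(C(=O)c2cccnc2)c2ccccn2)n1Cc1ccc(-c2ccccc2S(=O)(=O)NC(=O)OCCC(C)C)cc1F` is built from compound 2 by a different change: pyridin-2-yl in place of pyridin-3-yl on an amide-type nitrogen. No measured pair alters the ring on the amide-type nitrogen, so the step from compound 1 to compound 2 bears only by analogy, having shown that a move of a ring nitrogen can produce a modest change. For compound 3 the expected outcome is a step of about a 1.8-fold higher number from compound 2 to compound 3 (0.26 log units; within the scatter), most likely within the scatter, so compound 3 is estimated to give 0.4 nM in this assay, within a range of 0.1 nM to 1.5 nM.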

Compound 3, half-maximal inhibitory concentration: 0.16 nM
Estimate against measurement, compound 3: 2.5-fold (0.40 log units) above; the measured number falls inside the stated range.
By their numbers in this assay, from the lowest: compounds 3 and 2 (each within the scatter of the next); then compound 1.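

Going by these compounds alone, the first measured change to the ring on the amide-type nitrogen is the step of a 1.4-fold lower number from compound 2 to compound 3 (0.14 log units; within the scatter) in this assay and so, at this place, pyridin-2-yl and pyridin-3-yl cannot be told apart. A move of the ring nitrogen in the group on the carbonyl carbon gave a clearer result, a 4.5-fold lower number from compound 1 to compound 2 (0.66 log units; beyond the scatter) and beyond the scatter, so a move of this kind does not count equally at the two places in these compounds. Nothing available here explains this difference.

Still open, from the compounds shown here alone, is whether the amide-type nitrogen needs a ring containing nitrogen at all, which a phenyl ring or a methyl group there would test. Also open, going by these compounds, is how pyridin-4-yl would fare on that nitrogen, and how pyridin-2-yl would fare on the carbonyl carbon.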